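This account rests on a few compounds, and the source may have more. Where it says the series, first, only, none or still open, it means among the compounds named here.

Of the compounds shown here, three have been measured in an assay on isolated protein for inhibition of protein kinase C delta type (Homo sapiens), read by TR-FRET, with a stated time of 2 h; on this read-out lower numbers stand for stronger inhibition and higher numbers for weaker inhibition. Compound 1 `N#Cc1cnc(NCc2cnccc2C(F)(F)F)cc1NC[C@H]1C[C@@H](O)C1` gives 4200 nM, compound 2 `N#Cc1cnc(NCc2cnccc2C(F)(F)F)cc1N[C@H]1CC[C@H](O)CC1` gives 6500 nM, and compound 3 `CO[C@H]1CC[C@@H](Nc2cc(NCc3cnccc3C(F)(F)F)ncc2C#N)CC1` gives 5000 nM, which stands second highest of the three numbers, within the scatter of both others. The measured steps are all within the scatter: a 1.5-fold higher number from compound 1 to compound 2 (0.19 log units; within the scatter), a 1.2-fold higher number from compound 1 to compound 3 (0.08 log units; within the scatter) and a 1.3-fold lower number from compound 2 to compound 3 (0.11 log units; within the scatter). Compound 4 `CO[C@H]1CC[C@H](Nc2cc(NCc3cnccc3C(F)(F)F)ncc2C#N)CC1` differs from compound 3 only in configuration: the two compounds have the same atoms and bonds and differ only in configuration as drawn: 2 of 2 stereo elements differ (all stereocentres are inverted: mirror images); a stereocentre at a saturated ring carbon is drawn s in compound 3 and r in compound 4; a stereocentre at a saturated ring carbon is drawn s in compound 3 and r in compound 4. For the measured compounds named here, no measured step changes configuration alone, and every measured step in this assay lies within the scatter, so no step beyond the scatter is expected in either direction. Compound 4 is therefore estimated at 5000 nM, in the range 2500 nM to 10000 nM, an expected step of no change at the digits printed from compound 3 to compound 4 (within the scatter).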

Compound 4, half-maximal inhibitory concentration: > 10000 nM
Compound 4 gave a limit, no number; the forecaster's own chance of this, stated with the estimate: 5%; middle value at least 2.0-fold (0.30 log units) from the limit.
By their numbers in this assay, from the lowest: compounds 1, 3 and 2 (each within the scatter of the next). At a limit, above all of these: compound 4.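

In this assay compound 4 gives > 10000 nM, which is a limit of the assay and not a number. Configuration alone gives an at least 2.0-fold higher number from compound 3 to compound 4 (0.30 log units; that floor lies within the scatter), and methyl in place of hydrogen on the oxygen gives an at least 1.5-fold higher number from compound 2 to compound 4 (0.18 log units; that floor lies within the scatter), while the one step clearly beyond the scatter is an at least 2.3-fold higher number from compound 1 to compound 4 (0.37 log units; beyond the scatter). Unlike the earlier steps at this position, these show that the substituent on the nitrogen can leave the range of the first three compounds, with the full size of the change unknown.

Open, as far as these compounds go, is whether an amine or a carboxylic acid in place of the methoxy on the cyclohexyl would depend on configuration in the same way.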